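A methyl ortho to the aryl link in a lyase series

This account rests on a few compounds, and the source may have more. Where it says the series, first, only, none or still open, it means among the compounds named here.

Going by the values given here, compound 1, with the structure `Fc1ccc(-c2ccc3c(-c4cccnc4)cccc3c2)cc1`, stands at the lower of the two numbers so far measured: in an assay for inhibition of steroid 17-alpha-hydroxylase/17,20 lyase (Homo sapiens), tested at 2 uM (a lower number here means a weaker effect, a higher number a stronger effect of the compound at the concentration tested), compound 1 gives 3%. Its nearest measured neighbour is compound 2, `COc1ccc2cc(-c3ccc(F)cc3)ccc2c1-c1cccnc1`, which in this assay gives 7%; the step is a number 4 percentage points higher from compound 1 to compound 2 (within the scatter), a methoxy in place of hydrogen on an aromatic carbon.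

Compound 3, `Cc1cc(F)ccc1-c1ccc2c(-c3cccnc3)cccc2c1`, is not yet measured. It differs from compound 1 as follows: methyl in place of hydrogen on an aromatic carbon. The methyl sits ortho to a large group and meta to a fluoro group, so that the 4-fluorophenyl becomes a 4-fluoro-2-methylphenyl.

Among the compounds with values here, no measured step shows this exact change. Within the data shown here, the one step that bears on it, a small group added to an aromatic carbon of the core, was within the scatter. On that basis the expected step is a number 2 percentage points higher from compound 1 to compound 3 (within the scatter), none beyond the scatter. Compound 3 is therefore estimated at 5%, expected between -5% and 15%.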

Compound 3, a percentage reported as inhibition, at one concentration (the size of the read-out at that concentration, not a potency): 3%
For compound 3 the middle estimate is 2 percentage points above the measured one; measured number inside the range.
By their numbers in this assay, from the lowest: compounds 1, 3 and 2 (each within the scatter of the next).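

Replacing the 4-fluorophenyl with a 4-fluoro-2-methylphenyl gives, in this assay, no change at the digits printed from compound 1 to compound 3 (within the scatter), and this is the first step shown on the fluorinated aryl ring rather than on the shared core. A methyl on an aromatic carbon, ortho to a large group and meta to a fluoro group, therefore leaves the read-out at this concentration within the scatter, as the methoxy step on the core did. No separate measurement offers an explanation for this result.

The compounds shown leave open whether a larger or differently built group at this same place, such as a methoxy, an amine, a carboxylic acid or a longer chain, would move the number beyond the scatter. They also leave open whether a methyl elsewhere on this ring would behave the same way.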